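From fluoro to trifluoromethoxy in a growth inhibition series

This account rests on a few compounds, and the source may have more. Where it says the series, first, only, none or still open, it means among the compounds named here.

Compound 1 `Cc1ccc2[nH]c(-c3ccc(-c4ccc(-c5ccc(N(C)C)cc5)cc4)cc3)nc2c1` gives 6240 nM
Compound 2 `COc1ccc(-c2ccc(-c3ccc(-c4nc5cc(C)ccc5[nH]4)cc3)cc2)cc1OC` gives 2190 nM
Compound 3 `Cc1ccc2[nH]c(-c3ccc(-c4ccc(-c5ccc(F)cc5)cc4)cc3)nc2c1` gives 24900 nM

In a functional assay on KB cells (Homo sapiens) for inhibition, read by sulforhodamine B assay (on this read-out lower numbers stand for stronger inhibition of growth and higher numbers for weaker inhibition of growth), compound 3 stands highest of the three at 24900 nM and shows the weakest growth inhibition measured so far. Compound 4 `Cc1ccc2[nH]c(-c3ccc(-c4ccc(-c5ccc(OC(F)(F)F)cc5)cc4)cc3)nc2c1` differs from it by a single change (trifluoromethoxy in place of fluoro on an aromatic carbon), trifluoromethoxy in place of fluoro on an aromatic carbon, para to a large group. For the measured compounds named here, two measured steps bear on this, both ending at the fluoro compound: a modest one a 4.0-fold higher number from compound 1 to compound 3 (0.60 log units; beyond the scatter) and a large one an 11-fold higher number from compound 2 to compound 3 (1.06 log units; beyond the scatter). Neither involves trifluoromethoxy, so they give only a loose guide to direction. A modest move to a lower number is expected, and the estimated step is a 2.3-fold lower number from compound 3 to compound 4 (0.35 log units; beyond the scatter). For compound 4 the expected value is 11000 nM, with an estimated range from 3500 nM to 30000 nM.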

Compound 4, concentration for 50% growth inhibition: 41200 nM
The estimate for compound 4 lay 3.7-fold (0.57 log units) below the measured number; the measured number lies above the stated range.
By their numbers in this assay, from the lowest: compound 2; then compound 1; then compounds 3 and 4 (each within the scatter of the next).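

Trifluoromethoxy and fluoro are not separated at this position, with a 1.7-fold higher number from compound 3 to compound 4 (0.22 log units; within the scatter), so the larger group does not bring the lower number that the earlier steps pointed towards. Compound 4 stays well apart from the compounds with electron-rich-free naming aside, the 3,4-dimethoxyphenyl and dimethylamino groups, with a 19-fold higher number from compound 2 to compound 4 (1.27 log units; beyond the scatter) and a 6.6-fold higher number from compound 1 to compound 4 (0.82 log units; beyond the scatter). Nothing available explains this difference. The compounds shown leave open how a single methoxy, a primary amine or a carboxylic acid would compare at this place.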